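Moving the fluorine around the benzyl ring of compound 1

The compounds below may be only part of what the source reports. "The series", "measured", "known", "first", "only" and "open" are said of these compounds alone.

This account follows a single positional change within a family of dithiocarbamate-linked triazoles tested in a functional assay on MCF7 cells (Homo sapiens) for cytotoxicity, read by MTT assay, with a stated time of 24 h; on this read-out lower numbers stand for stronger inhibition and higher numbers for weaker inhibition. Compound 1 `Cc1ccc(/C=C2\CN(C(=S)SCc3cn(Cc4ccccc4F)nn3)C/C(=C\c3ccc(C)cc3)C2=O)cc1` is the starting point. In this assay compound 1 gives only a limit of the measurement, > 100000 nM, and no number; it sits at the limit of > 100000 nM in this assay, at which 1 of the 3 values shown sits. Two relatives give numbers. Compound 2 `Cc1ccc(/C=C2\CN(Cc3cn(Cc4ccccc4Cl)nn3)C/C(=C\c3ccc(C)cc3)C2=O)cc1` gives 66700 nM in this assay. Compound 3 `COc1ccc(/C=C2\CN(C(=S)SCc3cn(Cc4cccc(Cl)c4)nn3)C/C(=C\c3ccc(OC)cc3)C2=O)cc1` gives 32000 nM in this assay. Neither compound 2 nor compound 3 differs from compound 1 in one place only, so their values are reported here without any comparison drawn between them and compound 1.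

The unmeasured member is compound 4 `Cc1ccc(/C=C2\CN(C(=S)SCc3cn(Cc4ccc(F)cc4)nn3)C/C(=C\c3ccc(C)cc3)C2=O)cc1`. It differs from compound 1 as follows: 4-fluorophenyl in place of 2-fluorophenyl on a saturated chain carbon bound to an aromatic nitrogen. Going by the values given here, no measured pair in this set shares this difference, so no measured step is available to lean on. With every shown number for this family lying in the weakly inhibitory region, compound 4 is expected to remain weak as well, and the step of a number no higher from compound 1 to compound 4 (the limit leaves the size open) is expected to be none beyond the scatter. Compound 4 is therefore estimated at 100000 nM, with a range from 40000 nM to 250000 nM, and a real chance that this assay again reports only a limit for compound 4.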

Compound 4, half-maximal inhibitory concentration: 81600 nM
Compound 4: the middle estimate sits 1.2-fold (0.09 log units) above what was measured; low and high end bracket the measured number.
By their numbers in this assay, from the lowest: compound 3; then compounds 2 and 4 (each within the scatter of the next). At a limit, above all of these: compound 1.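

With 4-fluorophenyl in place of 2-fluorophenyl on a saturated chain carbon bound to an aromatic nitrogen, in this assay compound 4 gives 81600 nM and so stands as a measured number rather than a limit. The same atoms joined differently amount to an at least 1.2-fold lower number from compound 1 to compound 4 (0.08 log units; that floor lies within the scatter) and, as that floor is all that can be stated, the change is not shown to strengthen inhibition beyond the scatter. Compound 1 remains a limit of the assay and not a number, so the true size of the step cannot be read: the limit of > 100000 nM in this assay, at which 1 of the 4 values shown sits.

The compounds shown leave open whether the place of the fluorine matters at all for this read-out, as this one pair is the only comparison available at this position and one of its two members has no number. They also leave open what an amine or a carboxylic acid in place of the fluorine, or a longer chain in place of the saturated chain carbon, would do to the number in this assay for this family.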